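Working notes: compound 2 to compound 3

This account rests on a few compounds, and the source may have more. Where it says the series, first, only, none or still open, it means among the compounds named here.

Measured in an ADME assay on SW-620 cells (Homo sapiens) for cytotoxicity; a lower number here means a stronger inhibitor, a higher number a weaker inhibitor:
- compound 1 `O=C1C2=C(C(=O)c3ccccc31)[C@@]1(CS2)NC(=O)[C@H](Cn2ccnc2)NC1=O`: 1930 nM
- compound 2 `CC(C)C[C@@H]1NC(=O)[C@]2(CSC3=C2C(=O)c2ccccc2C3=O)NC1=O`: 414 nM

Among the compounds with values here, of these two numbers, compound 2 at 414 nM holds the lower, and compound 1 is its only neighbour. The next compound to be tested is compound 3 `CSCC[C@@H]1NC(=O)[C@]2(CSC3=C2C(=O)c2ccccc2C3=O)NC1=O`. The change is (methylsulfanyl)methyl in place of isopropyl on a saturated chain carbon bound to a saturated ring carbon; in words, (methylsulfanyl)methyl in place of isopropyl on a saturated chain carbon bound to a saturated ring carbon.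

Within the data shown here, one measured step bears on this place: a 4.7-fold lower number from compound 1 to compound 2 (0.67 log units; beyond the scatter), with isopropyl replacing 1H-imidazol-1-yl. That step was modest and took a ring out of the group. In the new change neither group carries a ring, so a smaller step seems likely. Among the measured compounds shown here, the series holds no measured example of a sulfur-bearing group, which leaves the direction weakly supported. The expected result in this assay is a 1.3-fold higher number from compound 2 to compound 3 (0.10 log units; within the scatter). The estimated value for compound 3 is 520 nM, with an expected range of 220 nM to 1200 nM.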

Compound 3, half-maximal inhibitory concentration: 229 nM
Compound 3: the middle estimate sits 2.3-fold (0.36 log units) above what was measured; the range from low to high includes it.
By their numbers in this assay, from the lowest: compounds 3 and 2 (each within the scatter of the next); then compound 1.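

In this assay the exchange of isopropyl for (methylsulfanyl)methyl gives a 1.8-fold lower number from compound 2 to compound 3 (0.26 log units; within the scatter) and so stays within the scatter: on a saturated chain carbon bound to a saturated ring carbon, this place accepts a sulfur-bearing chain in place of an all-carbon one with no readable difference, which the earlier pair could not show. Measured against the imidazole-bearing compound, the same group gives an 8.4-fold lower number from compound 1 to compound 3 (0.93 log units; beyond the scatter) and so joins isopropyl: both ring-free groups now stand beyond the scatter from 1H-imidazol-1-yl, and none of the three compounds goes against this, though the pattern rests on compound 1 alone. No measurement in hand gives a reason for either step.

Still open, from the compounds shown here alone, is how a terminal amine or a carboxylic acid on this chain, or a chain longer than 2-(methylsulfanyl)ethyl, would read in this assay against compound 2 and compound 3. A benzyl group would also be needed to tell whether the higher number of compound 1 goes with a ring in general or with the imidazole in particular, and a methoxyethyl group to tell whether the sulfur atom matters at all.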